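Benzyl on the ring nitrogen of the octadecyl imine

The source may hold more compounds than are shown below. What is called first, only, known or untested is meant among the compounds shown, and "the series" means these compounds.

Working notes on the series. Compound 1 `CCCCCCCCCCCCCCCCCC/N=c1\nc(N)c2nc[nH]c2c(N)n1` carries a hydrogen on the ring nitrogen of its core. Going by the values given here, in a functional assay on NCI-H460 cells (Homo sapiens) for antiproliferative activity, read by WST assay, with a stated time of 72 h (a lower number here means a stronger inhibitor, a higher number a weaker inhibitor), compound 1 gives 1750 nM, the lower of the two numbers so far. Among the compounds with values here, compound 2 `Nc1n/c(=N\CCCCc2ccccc2)nc(N)c2c1ncn2Cc1ccccc1` gives 18800 nM in this assay, a gap beyond the scatter; no single-point step links compound 1 and compound 2. Compound 3 `CCCCCCCCCCCCCCCCCC/N=c1\nc(N)c2ncn(Cc3ccccc3)c2c(N)n1` is compound 1 with benzyl in place of hydrogen on an aromatic nitrogen. Within the data shown here, no measured step of this kind exists here. A moderate rise in the number is expected, so the step of a 2.0-fold higher number from compound 1 to compound 3 (0.30 log units; within the scatter) is estimated with wide uncertainty. Compound 3 is accordingly expected near 3500 nM, within 900 nM to 14000 nM.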

Compound 3, half-maximal inhibitory concentration: 5400 nM
Compound 3: middle estimate off by 1.5-fold (0.19 log units), on the low side; the range from low to high includes it.
By their numbers in this assay, from the lowest: compound 1; then compound 3; then compound 2.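

Benzyl in place of hydrogen on the aromatic nitrogen is the first single-point change in the series, and in this assay it gives a 3.1-fold higher number from compound 1 to compound 3 (0.49 log units; beyond the scatter) as a modest loss of potency. With the octadecyl chain held fixed, this position tolerates the added benzyl without abolishing activity. Nothing available accounts for the size of this step.

Still open, from the compounds shown here alone, is whether a smaller methyl or a longer phenethyl on this ring nitrogen would differ from benzyl. Also open, going by these compounds, is whether a substituted benzyl, such as 4-methoxybenzyl, would shift the number.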